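Tetrazole to Carboxylic Acid on a Quinolinylmethoxyphenyl Chain

The source may hold more compounds than are shown below. What is called first, only, known or untested is meant among the compounds shown, and "the series" means these compounds.

Measured compounds:
compound 1 `CC(CCc1ccc(OCc2ccc3ccccc3n2)cc1)Cc1nnn[nH]1` with 25 nM;
compound 2 `O=C(O)CCCCc1cccc(OCc2ccc3ccccc3n2)c1` with 100 nM;
compound 3 `CC(CCCc1cccc(OCc2ccc3ccccc3n2)c1)C(=O)O` with 85 nM.

All three were tested in an assay on membranes from lung (Cavia porcellus) for binding affinity to cysteinyl leukotriene receptor (Homo sapiens); a lower number here means a stronger inhibitor, a higher number a weaker inhibitor. Compound 1 gives the lowest of the three numbers; compound 3 sits nearest to it and compound 2 furthest, both gaps being beyond the scatter. Compound 4 `CC(CCC(=O)O)Cc1ccc(OCc2ccc3ccccc3n2)cc1` has not yet been measured. It differs from compound 1 in one place: 3-carboxy-1-methylpropyl in place of 2-((1H-tetrazol-5-yl)methyl)propyl on a saturated chain carbon bound to an aromatic carbon. Within the data shown here, no measured pair mirrors this exchange of an acidic ring for a carboxylic acid. Among the measured compounds shown here, the only step on record, a 1.2-fold lower number from compound 2 to compound 3 (0.07 log units; within the scatter), concerns a methyl on the acid-bearing chain and lies within the scatter, so the branching methyl of compound 4 is not expected to matter by itself. Compounds 2 and 3 show that carboxylic acids on this shared core bind, though with higher numbers than compound 1. The account therefore expects a modest rise, a 2.4-fold higher number from compound 1 to compound 4 (0.38 log units; beyond the scatter), and estimates compound 4 at 60 nM, with a range from 20 nM to 200 nM.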

Compound 4, inhibition constant: 43 nM
The estimate for compound 4 lay 1.4-fold (0.14 log units) above the measured number, and the stated range covers the measured number.
By their numbers in this assay, from the lowest: compounds 1, 4, 3 and 2 (each within the scatter of the next, the first and the last beyond it).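

Among these compounds, at this position, on a saturated chain carbon bound to an aromatic carbon, the result gives the first direct reading of this exchange: in this assay, 3-carboxy-1-methylpropyl in place of 2-((1H-tetrazol-5-yl)methyl)propyl gives a 1.7-fold higher number from compound 1 to compound 4 (0.24 log units; within the scatter). On the shared core, the tetrazole ring can thus give way to an open chain ending in a carboxylic acid with a step that stays within the scatter, something compounds 2 and 3 could not show, as each differs from compound 1 in more than one place. No measurement at hand accounts for this result.

Still open, going by these compounds, is how a longer or shorter chain carrying the carboxylic acid would read at this position. Also open, on these data alone, is whether a primary amide or a sulfonamide could stand in place of the carboxylic acid there.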